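The source may hold more compounds than are shown below. What is called first, only, known or untested is meant among the compounds shown, and "the series" means these compounds.

Measured in an ADME assay on RAW264.7 cells (Mus musculus) for cytotoxicity, read by MTT assay, with a stated time of 72 h, tested at 50 uM; on this read-out lower numbers stand for a weaker effect and higher numbers for a stronger effect at the one concentration tested:
- compound 1, `O=C(Cn1c(=O)oc2ccccc21)Nc1cc(C(F)(F)F)ccc1Cl`, gives 12.3%
- compound 2, `O=C(Cn1c(=O)oc2cc(Cl)ccc21)Nc1ccccc1`, gives 15.8%
- compound 3, `O=C(Cn1c(=O)oc2cc(Cl)ccc21)Nc1nc2ccccc2s1`, gives 38.7%

Compound 1 has the smallest number of the three. Compound 2 sits within the usual scatter of it, so nothing separates the two on this read-out. Compound 3 lies beyond the scatter above compound 1, and the two differ in the amide substituent, the only thing the data show about that gap.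

The next compound is compound 4, `O=C(Cn1c(=O)oc2cc(Cl)ccc21)Nc1cc(C(F)(F)F)ccc1Cl`. Relative to compound 1 the change is chloro in place of hydrogen on an aromatic carbon, on the shared core, while the amide substituent of compound 1 is kept. For the measured compounds named here, no pair of measured compounds differing only in this way is available, so the size of the step cannot be read from a measured pair. Compound 2 carries the same chloro on the core and gives a number within the scatter of compound 1, which is the only hint on hand. On that basis the step in this assay is expected to be small, in either direction, and not beyond the scatter: the estimated step is a number 3.7 percentage points higher from compound 1 to compound 4 (within the scatter). The expected value for compound 4 is 16%, with a range from 5% to 30%.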

Compound 4, a percentage reported as inhibition, at one concentration (the size of the read-out at that concentration, not a potency): 1.61%
Compound 4: middle estimate off by 14.4 percentage points, on the high side; the measured number lies below the stated range.
By their numbers in this assay, from the lowest: compound 4; then compounds 1 and 2 (each within the scatter of the next); then compound 3.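

In this assay, for the compounds shown here, chloro in place of hydrogen on an aromatic carbon of the shared core gives the first readable step at this position, a number 10.7 percentage points lower from compound 1 to compound 4 (beyond the scatter), with the amide substituent of compound 1 kept. So this position is not silent on this read-out, and the direction is downward for this one amide substituent; one pair sets no rule for the position, and the chloro core alone does not fix the number, as compound 4 gives 1.61% while compound 2 gives 15.8% and compound 3 gives 38.7% on the same chlorinated core with other amide substituents. Nothing on hand speaks to why the number moves with this change.

From the compounds shown here alone, whether chloro at this position moves the number the same way under the amide substituents of compound 2 and compound 3 stays open, since the matching steps cannot be read. Also open, going by these compounds, is how a fluoro, a methoxy or an amine on this same aromatic carbon would compare with chloro and hydrogen under the amide substituent of compound 1.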